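This account rests on a few compounds, and the source may have more. Where it says the series, first, only, none or still open, it means among the compounds named here.

Measured so far in an assay for displacement of a labelled ligand from melanin-concentrating hormone receptor 1 (Homo sapiens), read by fluorescence; a higher number here means a weaker inhibitor, a lower number a stronger inhibitor:
compound 1 `COc1ccccc1-c1nc2ccccc2n1CCCN1CCC(c2cccc(NC(C)=O)c2)CC1`: 747 nM
compound 2 `CC(=O)Nc1cccc(C2CCN(CCCn3c(-c4ccc(Br)cc4)nc4ccccc43)CC2)c1`: 5 nM
compound 3 `CC(=O)Nc1cccc(C2CCN(CCCn3c(-c4ccc(C(C)C)cc4)nc4ccccc43)CC2)c1`: 60 nM

Compound 3 holds the second highest of the three numbers: the step of a 12-fold higher number from compound 2 to compound 3 (1.08 log units; beyond the scatter) separates it from compound 2 below, the step of a 12-fold lower number from compound 1 to compound 3 (1.10 log units; beyond the scatter) from compound 1 above.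

Compound 4 `CC(=O)Nc1cccc(C2CCN(CCCn3c(-c4ccc(Cl)cc4Cl)nc4ccccc43)CC2)c1` is not yet measured. Its change from compound 3 is 2,4-dichlorophenyl in place of 4-isopropylphenyl on an aromatic carbon. Going by the values given here, two measured steps bear on it. a 12-fold higher number from compound 2 to compound 3 (1.08 log units; beyond the scatter) shows that the halogen-bearing phenyl of compound 2 gave the lower number than the isopropyl-bearing phenyl of compound 3. a 150-fold lower number from compound 1 to compound 2 (2.17 log units; beyond the scatter) shows how far the pattern on that phenyl can move the read-out; compound 1 also shows that a second substituent on the pendant phenyl is not itself a guarantee of a low number. Among the compounds with values here, the second chlorine of compound 4 has no direct counterpart among the measured compounds.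

Compound 4 is expected to move back toward compound 2, by about a 4.0-fold lower number from compound 3 to compound 4 (0.60 log units; beyond the scatter). Compound 4 is therefore estimated at 15 nM, with a range from 4 nM to 60 nM.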

Compound 4, half-maximal inhibitory concentration: 3 nM
Compound 4: the middle estimate sits 5.0-fold (0.70 log units) above what was measured, and the stated range ends above it.
By their numbers in this assay, from the lowest: compounds 4 and 2 (each within the scatter of the next); then compound 3; then compound 1.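

In this assay, 2,4-dichlorophenyl on this carbon gives a 20-fold lower number from compound 3 to compound 4 (1.30 log units; beyond the scatter) and a 250-fold lower number from compound 1 to compound 4 (2.40 log units; beyond the scatter), placing both halogen-bearing phenyls at the low end, while 4-isopropylphenyl and 2-methoxyphenyl do not reach it. With a 1.7-fold lower number from compound 2 to compound 4 (0.22 log units; within the scatter), 2,4-dichlorophenyl and 4-bromophenyl cannot be told apart here, so the low number is not confined to the 4-bromophenyl of compound 2. No measurement on hand accounts for these steps.

Open, on these data alone, is whether 2-chlorophenyl or 4-chlorophenyl alone would match 2,4-dichlorophenyl. Also open, as far as these compounds go, is whether a phenyl carrying an amine or a carboxylic acid would keep the number this low.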